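Cytotoxicity series: aryl-ether variation at the phenoxy oxygen

This account rests on a few compounds, and the source may have more. Where it says the series, first, only, none or still open, it means among the compounds named here.

Compound 1 `Cc1cn(C2CCN(Cc3cccc(OC4CCCC4)c3)CC2)c(=O)[nH]c1=O`: 30300 nM
Compound 2 `Cc1cn(C2CCN(Cc3cccc(Oc4cccnc4)c3)CC2)c(=O)[nH]c1=O`: > 64000 nM

In an ADME assay on MRC5 cells (Homo sapiens) for cytotoxicity, read by fluorescence and resazurin assay, with a stated time of 3 days (on this read-out higher numbers stand for weaker inhibition and lower numbers for stronger inhibition), compound 1 gives 30300 nM. For compound 2 the result is a limit of the assay, > 64000 nM, as recorded in the limit of > 64000 nM in this assay, at which 1 of the 2 values shown sits. Among the compounds with values here, the one step measured, an at least 2.1-fold higher number from compound 1 to compound 2 (0.32 log units; beyond the scatter), is the only guide. Compound 3 `Cc1cn(C2CCN(Cc3cccc(Oc4cccc(OC(F)(F)F)c4)c3)CC2)c(=O)[nH]c1=O` carries the change (3-(trifluoromethoxy)phenyl in place of pyridin-3-yl on an oxygen on an aromatic ring). Since compound 2 sits at the limit, the expected step of an at least 1.6-fold lower number from compound 2 to compound 3 (0.20 log units; that floor lies within the scatter) is estimated as a modest fall in the number, toward compound 1. The expected value for compound 3 is 40000 nM, within 15000 nM to 100000 nM.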

Compound 3, half-maximal inhibitory concentration: 5260 nM
Beside the measured number, compound 3's estimate is 7.6-fold (0.88 log units) above it; the whole stated range lies above it.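

The group on the oxygen moves the number in this assay further than the first pair showed: there is an at least 12-fold lower number from compound 2 to compound 3 (1.08 log units; beyond the scatter) and a 5.8-fold lower number from compound 1 to compound 3 (0.76 log units; beyond the scatter) on going to 3-(trifluoromethoxy)phenyl. Compound 3 carries an aromatic ring of carbon only and stands lower than cyclopentyl compound 1, so an aromatic ring on the oxygen does not by itself raise the number. Compound 2 is a limit and not a number: the limit of > 64000 nM in this assay, at which 1 of the 3 values shown sits.

The compounds shown do not separate the loss of the pyridine nitrogen from the gain of the trifluoromethoxy group. An unsubstituted phenyl on the same oxygen would bear on that split.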